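The compounds below may be only part of what the source reports. "The series", "measured", "known", "first", "only" and "open" are said of these compounds alone.

In a functional assay on HepG2 cells (Homo sapiens) for cytotoxicity, read by MTT assay, with a stated time of 72 h (on this read-out lower numbers stand for stronger inhibition and higher numbers for weaker inhibition), compound 1 (`C=C(C)[C@@H]1CC[C@](C)(O)[C@H]1/C=C/C(C)=C/[C@@H]1C[C@@]23[C@H](OCCC[C@@H]2/C(=C(/C)C=O)CC[C@]3(C)O)O1`) gives > 10000 nM as a limit and not a number. Compound 2 (`C=C(C)[C@H]1CC[C@@](C)(O)[C@@H]1/C=C/C(C)=C/[C@@H]1C[C@@]23[C@H](OCCC[C@@H]2/C(=C(\C)C=O)CC[C@]3(C)O)O1`) gives > 10000 nM as a limit too. Compound 3 (`C=C(C)[C@@H]1CC[C@](C)(O)[C@H]1/C=C/C(C)=C/[C@@H]1C[C@@]2([C@H](OC)O1)[C@H](CCCO)/C(=C(/C)C=O)CC[C@]2(C)O`) gives > 10000 nM as a limit as well, so no order among the three can be read. Compound 4 (`C=C(C)[C@@H]1CC[C@](C)(O)[C@H]1/C=C/C(C)=C/[C@@H]1C[C@@]2([C@H](OC)O1)[C@H](CCCO)/C(=C(\C)C=O)CC[C@]2(C)O`) has not yet been measured, and it departs from compound 3 in one respect only (the two compounds have the same atoms and bonds and differ only in configuration as drawn: 1 of 11 stereo elements differ; a double bond is drawn Z in compound 3 and E in compound 4) with nothing leaving and nothing entering. Among the compounds with values here, the one measured step that bears on this is a step that the two limits leave unreadable from compound 1 to compound 2 and its size cannot be read. It is relevant through the fact that compounds 1 and 2 differ only in the configuration as drawn and includes a double bond drawn Z in compound 1 and E in compound 2. The other guide is the limit of > 10000 nM in this assay, at which 3 of the 3 values shown sit, and it offers no sign of activity in this series. The estimated step that the limit leaves unreadable from compound 3 to compound 4 is therefore expected to stay within the scatter with no direction to call in this assay at this stage. Compound 4 is expected at 15000 nM within an estimated range of 8000 nM to 40000 nM and will most likely be reported as a limit again.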

Compound 4, half-maximal inhibitory concentration: > 10000 nM
Compound 4 was reported as a limit; the forecaster's own chance of this, stated with the estimate: 90%; the middle value is on the limit's open side.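

Compound 3 and compound 4 are both reported only as limits in this assay, so the step between them, a double bond drawn Z and then E, cannot be read. The compounds shown leave open whether double-bond configuration affects the read-out in this assay at all.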